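Reversing the Benzyl Step with a Bromophenyl Amine

A few compounds are considered here, and "the series" means these few. Any claim that something is new, unique, unknown or untested is made for them only; others in the source may bear on it.

The shared core carries an amine nitrogen on which the substituent varies. Compound 1 `CCOc1ccc(NC2=CC(=O)c3c(nc4n3[C@H]3OC[C@@H](O)[C@H]3OC4)C2=O)cc1` returns only a limit in a functional assay on ECa-109 cells for inhibition, with ECa-109 cell line (Homo sapiens) as the target, read by sulforhodamine B assay (a higher number here means a weaker inhibitor, a lower number a stronger inhibitor), > 4000 nM. Compound 2 `O=C1C(Nc2ccccc2)=CC(=O)c2c1nc1n2[C@H]2OC[C@@H](O)[C@H]2OC1` gives 3560 nM in this assay. Compound 3 `O=C1C(NCc2ccccc2)=CC(=O)c2c1nc1n2[C@H]2OC[C@@H](O)[C@H]2OC1` also returns only a limit in this assay, > 8000 nM, so compound 3 stands without a number of its own, at the upper limit of what was read. Among the measured steps, an at least 2.2-fold higher number from compound 2 to compound 3 (0.35 log units; beyond the scatter), while an at least 1.1-fold lower number from compound 1 to compound 2 (0.05 log units; that floor lies within the scatter), and a step that the two limits leave unreadable from compound 1 to compound 3.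

Compound 4 `O=C1C(Nc2ccc(Br)cc2)=CC(=O)c2c1nc1n2[C@H]2OC[C@@H](O)[C@H]2OC1` differs from compound 3 in one place: 4-bromophenyl in place of benzyl on an amine nitrogen. The step from compound 2 to compound 3, benzyl in place of phenyl, bears most on this change and was at least modest; compound 4 reverses that move while adding bromine to the ring, and compound 1 shows that a group on that ring can leave the value at a limit. Compound 4 is therefore expected to show a downward step an at least 2.0-fold lower number from compound 3 to compound 4 (0.30 log units; that floor lies within the scatter) in this assay. The estimate for compound 4 is 4000 nM, with a range from 1500 nM to 12000 nM.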

Compound 4, half-maximal inhibitory concentration: 1980 nM
Compound 4: middle estimate off by 2.0-fold (0.31 log units), on the high side, within the range that was stated.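

Compound 4 shows that the loss seen with benzyl on this amine nitrogen does not persist once a substituted phenyl ring stands there, with an at least 4.0-fold lower number from compound 3 to compound 4 (0.60 log units; beyond the scatter). Bromo on that ring leaves compound 4 and compound 2 within the scatter of each other, at a 1.8-fold lower number from compound 2 to compound 4 (0.25 log units; within the scatter), so this ring carries bromo without a readable change in this assay. Against ethoxy the reading is an at least 2.0-fold lower number from compound 1 to compound 4 (0.30 log units; that floor lies within the scatter), which is only a floor and does not settle whether the two groups differ, since compound 1 rests at a limit: the limit of > 4000 nM in this assay, at which 1 of the 4 values shown sits.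

The compounds shown leave open whether a phenyl ring with a carboxylic acid or a dimethylamino group in place of bromo would hold this level. They also leave open how a chain longer than benzyl would read on this nitrogen.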